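Inverting the ring stereocentre in the pyridinylmethyl amine

This account rests on a few compounds, and the source may have more. Where it says the series, first, only, none or still open, it means among the compounds named here.

Compound 1 `Cc1cccc(C(=O)Nc2ccc3c(c2)C[C@@H](NS(C)(=O)=O)C3)c1-c1ccc(C(F)(F)F)cc1` gives 204 nM in an assay on isolated protein for inhibition of microsomal triglyceride transfer protein large subunit (Homo sapiens); on this read-out lower numbers stand for stronger inhibition and higher numbers for weaker inhibition. Compound 2 `Cc1cccc(C(=O)Nc2ccc3c(c2)C[C@H](NS(C)(=O)=O)C3)c1-c1ccc(C(F)(F)F)cc1` is the mirror partner of compound 1 at the ring carbon. In this assay compound 2 gives 34 nM. The step of a 6.0-fold lower number from compound 1 to compound 2 (0.78 log units; beyond the scatter) is assigned to configuration alone because of the fact that compounds 1 and 2 differ only in the configuration as drawn. Compound 3 `Cc1cccc(C(=O)Nc2ccc3c(c2)C[C@@H](NCc2ccccn2)C3)c1-c1ccc(C(F)(F)F)cc1` carries (pyridin-2-yl)methyl in place of the methylsulfonyl of compound 1. In this assay compound 3 gives 100 nM. That replacement is a 2.0-fold lower number from compound 1 to compound 3 (0.31 log units; beyond the scatter). Among the three numbers compound 3 stands second highest, below compound 1 and above compound 2.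

Compound 4 `Cc1cccc(C(=O)Nc2ccc3c(c2)C[C@H](NCc2ccccn2)C3)c1-c1ccc(C(F)(F)F)cc1` is not yet measured. It differs from compound 3 as follows: the two compounds have the same atoms and bonds and differ only in configuration as drawn: 1 of 1 stereo elements differ; a stereocentre at a saturated ring carbon is drawn S in compound 3 and R in compound 4. For the measured compounds named here, the only measured step of the same kind is a 6.0-fold lower number from compound 1 to compound 2 (0.78 log units; beyond the scatter), an inversion at the same ring carbon in the methylsulfonyl pair. The change from compound 1 to compound 3 was small, so the ring carbon is treated as behaving alike in both pairs, and a step of similar size and direction is expected, namely a 5.9-fold lower number from compound 3 to compound 4 (0.77 log units; beyond the scatter). Compound 4 is therefore estimated at 17 nM, with a range of 7 nM to 45 nM.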

Compound 4, half-maximal inhibitory concentration: 410 nM
Compound 4: the middle estimate sits 24-fold (1.38 log units) below what was measured, outside the stated range (above it).
By their numbers in this assay, from the lowest: compound 2; then compound 3; then compounds 1 and 4 (each within the scatter of the next).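

In this assay the effect of inverting the ring carbon depends on the group on the amine nitrogen: with (pyridin-2-yl)methyl there is a 4.1-fold higher number from compound 3 to compound 4 (0.61 log units; beyond the scatter) and with methylsulfonyl there is a 6.0-fold lower number from compound 1 to compound 2 (0.78 log units; beyond the scatter) in the opposite direction. The result for the pyridinylmethyl pair is assigned to configuration alone because nothing else separates the two structures: the fact that compounds 3 and 4 differ only in the configuration as drawn. The replacement on the amine nitrogen does not carry over between the two configurations either, since the drawn R form shows a 12-fold higher number from compound 2 to compound 4 (1.08 log units; beyond the scatter) and the two replacement steps diverge: the same change on two cores in this assay, a 2.0-fold lower number (0.31 log units; beyond the scatter) from compound 1 to compound 3 and a 12-fold higher number (1.08 log units; beyond the scatter) from compound 2 to compound 4, 25-fold (1.39 log units) apart, beyond the scatter of two such steps.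

The compounds shown leave open whether the reversal is specific to (pyridin-2-yl)methyl or would also appear with a plain benzyl group or an acetyl group on the same nitrogen. They also leave open which of the two configurations gives the lower number for any such group.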